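A few compounds are considered here, and "the series" means these few. Any claim that something is new, unique, unknown or untested is made for them only; others in the source may bear on it.

Going by the values given here, in an ADME assay on microsomes from liver (Rattus norvegicus) for metabolic stability (a higher number here means faster removal of the compound, a lower number slower removal), compound 1 (`CNc1nc(NC2(C#N)CCCCC2)nc(-n2cccn2)n1`) gives 103 mL/min/kg and compound 2 (`CNc1nc(NC2(C#N)CCCCC2)nc(-n2cnc(C#N)n2)n1`) gives 210 mL/min/kg, the higher of the two numbers so far. Compound 3 (`CNc1nc(NC2(C#N)CCCCC2)nc(-n2cnc(C)n2)n1`) follows from compound 2 with methyl in place of cyano on an aromatic carbon. Among the compounds with values here, only one measured step bears on this change: a 2.0-fold higher number from compound 1 to compound 2 (0.31 log units; beyond the scatter), a modest step beyond the scatter, with 3-cyano-1H-1,2,4-triazol-1-yl in place of 1H-pyrazol-1-yl. Within the data shown here, that step is a loose guide, since no measured pair changes the cyano alone. Going by a 2.0-fold higher number from compound 1 to compound 2 (0.31 log units; beyond the scatter), a modest move back towards a lower number is expected in this assay, though it may not clear the scatter. The expected step is a 1.6-fold lower number from compound 2 to compound 3 (0.21 log units; within the scatter). The estimate for compound 3 is 130 mL/min/kg, with an expected range of 70 mL/min/kg to 230 mL/min/kg.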

Compound 3, clearance: > 276 mL/min/kg
Compound 3 was reported as a limit; the forecaster's own chance of this, stated with the estimate: 3%; middle value at least 2.1-fold (0.32 log units) from the limit.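

In this assay compound 3 is reported only as a limit, not as a number: the limit of > 276 mL/min/kg in this assay, at which 1 of the 3 values shown sits. Methyl in place of cyano on this aromatic carbon brings no move towards slower removal: the reading is an at least 1.3-fold higher number from compound 2 to compound 3 (0.11 log units; that floor lies within the scatter), and since that is only a floor, the true size of the step stays unknown. Against 1H-pyrazol-1-yl, 3-methyl-1H-1,2,4-triazol-1-yl gives an at least 2.6-fold higher number from compound 1 to compound 3 (0.42 log units; beyond the scatter), so with either cyano or methyl on this carbon the substituted triazolyl group reads higher than the pyrazolyl group.

From the compounds shown here alone, how far the clearance of compound 3 lies past the limit remains open. Also open, going by these compounds, is whether the unsubstituted 1H-1,2,4-triazol-1-yl, or a carboxylic acid or an amine on this carbon, would give a lower number.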